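This account rests on a few compounds, and the source may have more. Where it says the series, first, only, none or still open, it means among the compounds named here.

Among the measured compounds shown here, in a functional assay on RKO cells (Homo sapiens) for cytotoxicity, read by resazurin assay, with a stated time of 72 h (a lower number here means a stronger inhibitor, a higher number a weaker inhibitor), compound 1 (`COc1cccc(Nc2nc(-n3cc(C)nc3C)cs2)c1`) gives 60000 nM, the only true number so far in this small set. Compound 2 (`Cc1nccn1-c1csc(Nc2ccccc2)n1`) stands at > 100000 nM, which is a limit of the assay and not a number. Compound 3 (`COc1cccc(Nc2nc(-n3ccnc3C)cs2)c1`) departs from compound 2 by a single change, methoxy in place of hydrogen on an aromatic carbon. For the measured compounds named here, no measured step isolates this change, so its size in this assay can only be judged indirectly. The judgement rests on compound 1, which also bears a methoxy and gives 60000 nM. A modest move towards stronger inhibition is therefore expected, and compound 3 may still reach the limit. The expected change is an at least 1.6-fold lower number from compound 2 to compound 3 (0.22 log units; that floor lies within the scatter). For compound 3 the estimated value is 60000 nM, with an expected range of 25000 nM to 100000 nM.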

Compound 3, half-maximal inhibitory concentration: > 100000 nM
Compound 3 was reported as a limit (the forecaster's own chance of this, stated with the estimate: 30%); at least 1.6-fold (0.22 log units) between middle value and limit.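

In this assay compound 3 gives > 100000 nM, which is a limit of the assay and not a number. The step that adds methoxy in place of hydrogen on an aromatic carbon cannot be read, as both of its ends are limits: the limit of > 100000 nM in this assay, at which 2 of the 3 values shown sit.

Hydrogen in place of methyl on an aromatic carbon gives an at least 1.6-fold higher number from compound 1 to compound 3 (0.22 log units; that floor lies within the scatter), so the methyl may matter in this series, but a floor of this size does not establish a real loss.

On these data alone, the true size of that step stays open, as does whether methoxy changes the number at all when that methyl is present. As far as these compounds go, it is also open how an amine or a carboxylic acid would compare with methoxy on the same aromatic carbon.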